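The compounds below may be only part of what the source reports. "The series", "measured", "known", "first", "only" and "open" are said of these compounds alone.

Measured compounds:
- compound 1, `O=C(NC1CCN(C2CC2)C1)c1cc(-c2ccc(NS(=O)(=O)c3cccc(Cl)c3Cl)cc2)nc2[nH]ncc12`, in an assay for inhibition of serine/threonine-protein kinase Sgk1 (Homo sapiens), with stated times of 30 min and 60 min, in the presence of a further agent that is not named here; on this read-out lower numbers stand for stronger inhibition and higher numbers for weaker inhibition: 610 nM
- compound 2, `O=C(NC1CCN(CC2CC2)C1)c1cc(-c2ccc(NS(=O)(=O)c3cccc(Cl)c3Cl)cc2)nc2[nH]ncc12`, in this assay: 35 nM

Compound 2 stands lowest of the two numbers in this assay; its nearest neighbour is compound 1, and the gap between them is a 17-fold lower number from compound 1 to compound 2 (1.24 log units; beyond the scatter). Among the measured compounds shown here, that single step is the only guide here: it shows that the group on the amine nitrogen in the ring matters strongly for this read-out, with the larger cyclopropylmethyl giving the much lower number.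

Compound 3, `CN1CCC(CNC(=O)c2cc(-c3ccc(NS(=O)(=O)c4cccc(Cl)c4Cl)cc3)nc3[nH]ncc23)C1`, is not yet measured. Its difference from compound 2 is (1-methylpyrrolidin-3-yl)methyl in place of 1-(cyclopropylmethyl)pyrrolidin-3-yl on an amide-type nitrogen. Two things change at once: the amine nitrogen now carries a methyl in place of the cyclopropylmethyl, and the amide-type nitrogen is joined to the ring through a further carbon. For the measured compounds named here, because a 17-fold lower number from compound 1 to compound 2 (1.24 log units; beyond the scatter) showed a large change when only the amine substituent was altered, and methyl is the smaller group, a large step towards a higher number is expected, though the extra carbon has no measured counterpart. Compound 3 is therefore estimated at 300 nM, within 60 nM to 1500 nM, which is expected to mean an 8.6-fold higher number from compound 2 to compound 3 (0.93 log units; beyond the scatter).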

Compound 3, half-maximal inhibitory concentration: 45 nM
The estimate for compound 3 lay 6.7-fold (0.82 log units) above the measured number; measured number outside the range, below it.
By their numbers in this assay, from the lowest: compounds 2 and 3 (each within the scatter of the next); then compound 1.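

In this assay, the cyclopropylmethyl group of compound 2 turns out not to be needed for a low number: the step of a 1.3-fold higher number from compound 2 to compound 3 (0.11 log units; within the scatter) lies within the scatter, even though (1-methylpyrrolidin-3-yl)methyl has fewer heavy atoms and no three-membered ring. The position therefore tolerates more than one group, and the step of a 14-fold lower number from compound 1 to compound 3 (1.13 log units; beyond the scatter) leaves compound 1, with its 1-cyclopropylpyrrolidin-3-yl group, as the only one of the three with a clearly higher number. No measurement here offers an explanation for these results.

Going by these compounds, compound 3 alters the group on the ring amine and adds a carbon to the link from the amide-type nitrogen in a single step, so the contribution of each change stays unknown. A 1-methylpyrrolidin-3-yl group or a (1-(cyclopropylmethyl)pyrrolidin-3-yl)methyl group on the amide-type nitrogen would separate the two changes, while an ethyl group on the ring amine would show how the number responds to a chain only slightly longer than methyl.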